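The compounds below may be only part of what the source reports. "The series", "measured", "known", "first", "only" and "open" are said of these compounds alone.

Working notes on the series. Compound 2 `Cc1ccc(NC(=O)NC(=O)c2ccc(OCc3cccc(Cl)c3Cl)cc2)cc1-c1nc2ccccc2[nH]1` carries the highest number of the two measured in a functional assay on MNK45 cells (Homo sapiens) for inhibition, read by MTT assay, with a stated time of 48 h; on this read-out higher numbers stand for weaker inhibition and lower numbers for stronger inhibition: compound 2 gives 87000 nM, while its nearest neighbour compound 1 `Cc1ccc(NC(=O)NC(=O)c2ccc(OCc3ccc(C(F)(F)F)cc3)cc2)cc1-c1nc2ccccc2[nH]1` gives 16800 nM, the difference being a 5.2-fold higher number from compound 1 to compound 2 (0.71 log units; beyond the scatter). Compound 3 `Cc1ccc(COc2ccc(C(=O)NC(=O)Nc3ccc(C)c(-c4nc5ccccc5[nH]4)c3)cc2)cc1` is not yet measured; it differs from compound 2 by 4-methylphenyl in place of 2,3-dichlorophenyl on a saturated chain carbon bound to an oxygen on an aromatic ring. For the measured compounds named here, the only measured step that touches this position is the one from compound 1 to compound 2, where replacing the benzyl substituent raised the number by a 5.2-fold higher number from compound 1 to compound 2 (0.71 log units; beyond the scatter); that step shows the position tolerates change of this size in this assay, but it involves a different pair of groups and gives no direct read on 4-methylphenyl. On the two numbers shown, the expected step for compound 3 is a return toward the lower end of the measured range, estimated as a 3.5-fold lower number from compound 2 to compound 3 (0.54 log units; beyond the scatter), with the width of the range reflecting that a single step is the whole basis. The estimate for compound 3 in this assay is 25000 nM, within a range of 8000 nM to 80000 nM.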

Compound 3, half-maximal inhibitory concentration: 6360 nM
For compound 3 the middle estimate is 3.9-fold (0.59 log units) above the measured one; measured number outside the range, below it.
By their numbers in this assay, from the lowest: compound 3; then compound 1; then compound 2.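

In this assay, 4-methylphenyl in place of 2,3-dichlorophenyl gives a 14-fold lower number from compound 2 to compound 3 (1.14 log units; beyond the scatter), a large step that shows this position can move the number further than the earlier modest step did, and in the favourable direction. The pair that keeps the ring and changes one group on it adds a closer read: methyl in place of trifluoromethyl on an aromatic carbon gives a 2.6-fold lower number from compound 1 to compound 3 (0.42 log units; beyond the scatter), which places compound 3 as the strongest of the three, with both of its steps beyond the scatter. Nothing shown accounts for these differences.

The step from 2,3-dichlorophenyl to 4-methylphenyl changes the groups on the ring and where they sit in one move, so the compounds shown do not separate those two contributions. Also open, going by these compounds, is how an unsubstituted phenyl, or a ring carrying a methoxy group or an amine, would compare with compound 3 at this position, and whether the order seen here holds when the shared core is changed.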